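This account rests on a few compounds, and the source may have more. Where it says the series, first, only, none or still open, it means among the compounds named here.

Compound 1 `O=S(=O)(NCCCNCC1COc2ccccc2O1)c1cc(C(F)(F)F)cc(C(F)(F)F)c1` gives 2700 nM in a functional assay on HPAC cells (Homo sapiens) for inhibition, read by MTT assay, with a stated time of 72 h; on this read-out lower numbers stand for stronger inhibition of growth and higher numbers for weaker inhibition of growth.
Compound 2 `O=S(=O)(NCCCNCc1ccc(C(F)(F)F)cc1)c1cc(C(F)(F)F)cc(C(F)(F)F)c1` gives 2700 nM in this assay.
Compound 3 `O=S(=O)(NCCCNCc1ccccc1)c1cc(C(F)(F)F)cc(C(F)(F)F)c1` gives 3200 nM in this assay.

All three compounds share the same sulfonamide core and chain; they differ only in the group carried on the saturated chain carbon bound to the amine nitrogen. Compound 3 stands alongside the other two rather than apart from them: a 1.2-fold higher number from compound 1 to compound 3 (0.07 log units; within the scatter) and a 1.2-fold higher number from compound 2 to compound 3 (0.07 log units; within the scatter), and likewise no change at the digits printed from compound 1 to compound 2 (within the scatter).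

Compound 4 `O=S(=O)(NCCCNCc1cccc2ccccc12)c1cc(C(F)(F)F)cc(C(F)(F)F)c1` is the next step from compound 3, the change being (naphthalen-1-yl in place of phenyl on a saturated chain carbon bound to an amine nitrogen). For the measured compounds named here, the steps that bear on it are the earlier swaps at this same chain carbon, from compound 1 to compound 2 and from compound 1 to compound 3, both within the scatter, and the smaller swap from compound 2 to compound 3, also within the scatter. Going by the values given here, nothing measured so far suggests that this position moves the read-out. For compound 4 the expected outcome in this assay is therefore no change at the digits printed from compound 3 to compound 4 (within the scatter), no step beyond the scatter. Compound 4 is estimated at 3200 nM, with a range from 1500 nM to 6500 nM.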

Compound 4, concentration for 50% growth inhibition: 2400 nM
For compound 4 the middle estimate is 1.3-fold (0.12 log units) above the measured one; measured number inside the range.
By their numbers in this assay, from the lowest: compounds 4, 1, 2 and 3 (each within the scatter of the next).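

Going from phenyl to naphthalen-1-yl adds a second six-membered aromatic ring at this chain carbon, yet this assay shows only a 1.3-fold lower number from compound 3 to compound 4 (0.12 log units; within the scatter). The larger group also stands level with the two other groups at this carbon (a 1.1-fold lower number from compound 2 to compound 4 (0.05 log units; within the scatter) and a 1.1-fold lower number from compound 1 to compound 4 (0.05 log units; within the scatter)), so among these four compounds, this position tolerates a two-ring aromatic group with no step beyond the scatter. No measurement shown here offers an explanation for this flat result.

Still open, as far as these compounds go, is whether a group of another kind at this chain carbon, such as a carboxylic acid or a primary amine, would move the number in this assay. Also open, from the compounds shown here alone, is whether a longer chain in place of the shared one would change the read-out.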